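Benzyl in place of thiazolylmethyl on the shared core

This account rests on a few compounds, and the source may have more. Where it says the series, first, only, none or still open, it means among the compounds named here.

Within the data shown here, compound 1 `CCOc1cc(C2CCN(C)CC2)ccc1Nc1ncc2c(n1)N(Cc1sccc1C)[C@H](CC)C(=O)N2C` is the only member of this set with a number: in an assay on isolated protein for inhibition of serine/threonine-protein kinase PLK1 (Homo sapiens), read by Z'-LYTE, with a stated time of 60 min (a lower number here means a stronger inhibitor, a higher number a weaker inhibitor), compound 1 gives 68 nM. Among the measured compounds shown here, compound 2 `CCOc1cc(C2CCN(C)CC2)ccc1Nc1ncc2c(n1)N(Cc1scnc1C)[C@H](CC)C(=O)N2C` shares the core of compound 1 and was run in this assay, where compound 2 gives "not determined" (no result reported), so compound 2 stands without a number of its own and no step from compound 1 to compound 2 can be read. Compound 3 `CCOc1cc(C2CCN(C)CC2)ccc1Nc1ncc2c(n1)N(Cc1ccccc1)[C@H](CC)C(=O)N2C` is not yet measured; relative to compound 2 the change is phenyl in place of 4-methyl-1,3-thiazol-5-yl on a saturated chain carbon bound to a nitrogen on an aromatic ring in a ring. For the measured compounds named here, with no measured pair to anchor the step, there is no basis for expecting a move beyond the usual scatter in this assay in either direction; the only reference point is compound 1 at 68 nM. On that reference compound 3 is expected to give about 80 nM in this assay, with an estimated range from 25 nM to 300 nM.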

Compound 3, half-maximal inhibitory concentration: 290 nM
The estimate for compound 3 lay 3.6-fold (0.56 log units) below the measured number, and the stated range covers the measured number.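

In this assay, among these compounds, the first readable step at this position is a 4.3-fold higher number from compound 1 to compound 3 (0.63 log units; beyond the scatter), with phenyl in place of 3-methylthiophen-2-yl on a saturated chain carbon bound to a nitrogen on an aromatic ring in a ring, so the group held here does change the number beyond the scatter on the shared core. The step between compound 2 and compound 3 cannot be read, as compound 2 carries no number, and the 4-methyl-1,3-thiazol-5-yl group therefore remains unplaced relative to the other two groups. Nothing available bears on what lies behind the step from the methylthiophene to the phenyl group.

The change in compound 3 removes the ring sulfur and the methyl group of compound 1 together, so the compounds shown leave open which of the two, if either, accounts for the step. Unsubstituted thiophen-2-yl, a tolyl group or a pyridinyl ring at this position would pull those two changes apart, and the compounds shown give no reading for any of them.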